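The compounds below may be only part of what the source reports. "The series", "measured", "known", "first", "only" and "open" are said of these compounds alone.

Series notes. Compound 1 `CCN1CCN(CC(=O)Nc2nc3ccccc3[nH]2)CC1` and compound 2 `O=C(CN1CCN(c2ccccc2)CC1)Nc1nc2ccccc2[nH]1` share one core and differ on an amine nitrogen in a ring. In a functional assay, read by spectrophotometry, with a stated time of 30 min, tested at 150 ug/mL (on this read-out lower numbers stand for a weaker effect and higher numbers for a stronger effect at the one concentration tested), compound 1 gives 57.5%, and compound 2 gives 40.6%; compound 2 stands lowest of the two, the step of a number 16.9 percentage points lower from compound 1 to compound 2 (beyond the scatter). Compound 3 `O=C(CN1CCN(c2ccccn2)CC1)Nc1nc2ccccc2[nH]1` is not yet measured. Change: pyridin-2-yl in place of phenyl on an amine nitrogen in a ring. Within the data shown here, no measured step swaps one aromatic ring for another, so the only measured step is not a direct guide. An expected step of a number 1.4 percentage points higher from compound 2 to compound 3 (within the scatter) is therefore set within the scatter. Compound 3 is estimated at 42%, in the range 28% to 58%.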

Compound 3, a percentage reported as activity, at one concentration (the size of the read-out at that concentration, not a potency): 69.1%
For compound 3 the middle estimate is 27.1 percentage points below the measured one, and the stated range ends below it.
By their numbers in this assay, from the lowest: compound 2; then compound 1; then compound 3.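

Pyridin-2-yl in place of phenyl on this amine nitrogen in a ring gives, in this assay, a number 28.5 percentage points higher from compound 2 to compound 3 (beyond the scatter), so the outcome at this position depends on which aromatic ring is attached, even with the heavy-atom count unchanged. An aromatic ring here does not always lower the number, as pyridin-2-yl in place of ethyl gives a number 11.6 percentage points higher from compound 1 to compound 3 (beyond the scatter). Nothing available explains either step.

On these data alone, whether pyridin-3-yl, pyridin-4-yl or pyrimidin-2-yl would read like pyridin-2-yl remains open. So does the reading with a benzyl group or a longer chain on the same nitrogen.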